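The source may report more compounds than this note shows. Statements on the series, on what has been measured and on what is new or still open speak of the compounds shown alone.

Compound 1 `N#Cc1cccc(C(c2ccccc2)N2CCN(c3ncnc4c3cnn4-c3ccccc3)CC2)c1` is one of two compounds already tested in a functional assay on cells (Rhabdomyosarcoma cell, Homo sapiens) for cytotoxicity; on this read-out lower numbers stand for stronger inhibition and higher numbers for weaker inhibition. In this assay compound 1 gives > 25000 nM, which is a limit of the assay and not a number. Its companion, compound 2 `Cc1ccccc1C(c1sccc1C)N1CCN(c2ncnc3c2cnn3-c2ccccc2)CC1`, gives > 25000 nM in this assay, again a limit rather than a measured value. Both results sit at the limit of > 25000 nM in this assay, at which 2 of the 2 values shown sit, so compound 1 cannot be placed relative to compound 2; together the two show only that neither reaches measurable inhibition. The compound now in question is compound 3 `c1ccc(C(c2cccnc2)N2CCN(c3ncnc4c3cnn4-c3ccccc3)CC2)cc1`. It differs from compound 1 by pyridin-3-yl in place of 3-cyanophenyl on a saturated chain carbon bound to an amine nitrogen in a ring and an aromatic carbon. Within the data shown here, no step between measured compounds exists to weigh this change, and nothing among the measured compounds points away from the limit. The step from compound 1 to compound 3 in this assay is therefore expected to be a step that the limit leaves unreadable from compound 1 to compound 3, none beyond the scatter. Compound 3 is expected to give about 30000 nM in this assay, with a range from 12000 nM to 80000 nM, most likely reported as a limit once more.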

Compound 3, half-maximal inhibitory concentration: > 25000 nM
Compound 3: only a limit was reported; the forecaster's own chance of this, stated with the estimate: 80%; the middle value is on the limit's open side.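

In this assay compound 3 gives > 25000 nM, which is a limit of the assay and not a number. Among these compounds, no step from compound 1 to compound 3 can therefore be read. The compounds shown leave open how pyridin-3-yl and 3-cyanophenyl compare, and whether any of these compounds reaches measurable inhibition: the limit of > 25000 nM in this assay, at which 3 of the 3 values shown sit.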